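The source may report more compounds than this note shows. Statements on the series, on what has been measured and on what is new or still open speak of the compounds shown alone.

Among the measured compounds shown here, compound 2 `CCc1nc(-c2ccc(COc3cc(C(=O)NO)ccc3OC)cc2)no1` is the one compound with a number in an assay on isolated protein for inhibition of sphingomyelin phosphodiesterase (Homo sapiens), read by fluorescence, with a stated time of 30 min (on this read-out lower numbers stand for stronger inhibition and higher numbers for weaker inhibition), where compound 2 gives 8220 nM. Compound 1 `O=C(NO)c1cccc(OCc2ccc(-c3noc(-c4ccccc4)n3)cc2)c1` is reported only as a limit in this assay, at which compound 1 gives > 100000 nM; that is the limit of > 100000 nM in this assay, at which 1 of the 2 values shown sits. Compound 3 `COc1ccc(C(=O)NO)cc1OCc1ccc(-c2noc(-c3ccccc3)n2)cc1` has not yet been measured in this assay. It differs from compound 2 in one place: phenyl in place of ethyl on an aromatic carbon, on the five-membered aromatic ring with two nitrogen and one oxygen. For the measured compounds named here, no measured step of this kind is available, so the size of the step from compound 2 to compound 3 can only be expected, and the expectation here is a weakening beyond the scatter, with some chance that only a limit is returned. Compound 3 is expected to give 25000 nM in this assay, within 6000 nM to 100000 nM, a step of a 3.0-fold higher number from compound 2 to compound 3 (0.48 log units; beyond the scatter).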

Compound 3, half-maximal inhibitory concentration: 15900 nM
Beside the measured number, compound 3's estimate is 1.6-fold (0.20 log units) above it; the measured number falls inside the stated range.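

On the five-membered aromatic ring with two nitrogen and one oxygen, phenyl and ethyl are not separated in this assay: the exchange reads a 1.9-fold higher number from compound 2 to compound 3 (0.29 log units; within the scatter), so this aromatic carbon accepts either group without a change beyond the scatter. With phenyl kept in that place, methoxy in place of hydrogen on an aromatic carbon of the shared core gives an at least 6.2-fold lower number from compound 1 to compound 3 (0.79 log units; beyond the scatter), which shows that this second position can move the read-out where the first did not. Compound 1 stands only as a limit, so that step is a bound and not a size: the limit of > 100000 nM in this assay, at which 1 of the 3 values shown sits.

From the compounds shown here alone, it remains open whether an ethoxy group or a hydroxyl group would act as methoxy does at that aromatic carbon. Going by these compounds, it is also open whether an amine or a carboxylic acid on the five-membered ring would leave the read-out as unchanged as phenyl and ethyl do.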